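The compounds below may be only part of what the source reports. "The series", "measured", "known", "first", "only" and "open" are said of these compounds alone.

Compound 1 `CC(=O)c1cccc(-c2ccc(C(=O)N(Cc3cccc(OCCCCCC(=O)O)c3)C(C)C)cc2)c1` was tested in an ADME assay on BJ cells (Homo sapiens) for cytotoxicity, read by CellTiter-Glo and resazurin assay, with a stated time of 72 h; on this read-out lower numbers stand for an effect already at smaller amounts and higher numbers for an effect only at larger amounts of compound. In this assay compound 1 gives > 26000 nM, which is a limit of the assay rather than a number. Compound 2 `CC(C)N(Cc1cccc(OCCCCCC(=O)O)c1)C(=O)c1ccc(-c2cccc(Oc3ccccc3)c2)cc1` carries a phenoxy in place of the acetyl on an aromatic carbon. In this assay compound 2 gives > 18700 nM, again a limit and not a number. The step that the two limits leave unreadable from compound 1 to compound 2 therefore cannot be read, since both of its ends rest on limits the limit of > 18700 nM in this assay, at which 1 of the 2 values shown sits, and (the limit of > 26000 nM in this assay, at which 1 of the 2 values shown sits). Going by the values given here, compound 2 thus stands at a limit, and the only other value known here is a limit as well. The unmeasured compound 3 `CCOc1cccc(-c2ccc(C(=O)N(Cc3cccc(OCCCCCC(=O)O)c3)C(C)C)cc2)c1` differs from compound 2 by ethyl in place of phenyl on an oxygen on an aromatic ring. Among the compounds with values here, the one measured step, from compound 1 to compound 2, touches the same part of the molecule, but its size is not readable, so it gives no direction. With both known values sitting at limits, the expectation for a step that the limit leaves unreadable from compound 2 to compound 3 is no step beyond the scatter, and the reading for compound 3 is expected most likely to be a limit once more. Compound 3 is estimated at 25000 nM, from 10000 nM to 60000 nM.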

Compound 3, half-maximal effective concentration: > 20800 nM
Compound 3: only a limit was reported (the forecaster's own chance of this, stated with the estimate: 85%); the middle value lies beyond the limit too.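

Compound 3, like compound 1 and compound 2, reads only as a limit of the assay, so no step among these three compounds can be read. The compounds shown leave open where in this assay any of them would give a real number, and whether swapping acetyl, phenoxy and ethoxy changes that number at all.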